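The source may hold more compounds than are shown below. What is called first, only, known or untested is meant among the compounds shown, and "the series" means these compounds.

Of the compounds shown here, two built on one shared core have been tested in an assay on isolated protein for inhibition of tyrosine-protein kinase receptor UFO (Homo sapiens), read by FRET and Z'-LYTE, with a stated time of 1.5 h; on this read-out higher numbers stand for weaker inhibition and lower numbers for stronger inhibition. Compound 1, `Cc1c(C(=O)Nc2ccc(Oc3ncnc4[nH]cc(-c5ccccc5)c34)c(F)c2)c(=O)c2c(Cl)cccc2n1C`, reaches only a limit of the assay, > 10000 nM, rather than a number. Compound 1 therefore sits at the limit of > 10000 nM in this assay, at which 1 of the 2 values shown sits. Among the measured compounds shown here, compound 2, `Cc1c(C(=O)Nc2ccc(Oc3ncnc4[nH]cc(-c5ccccc5)c34)c(F)c2)c(=O)c2cc(Cl)ccc2n1C`, gives 1890 nM in this assay, and that is the only number among the values shown.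

Compound 3, `Cc1c(C(=O)Nc2ccc(Oc3ncnc4[nH]cc(-c5ccccc5)c34)c(F)c2)c(=O)c2cc(C(F)(F)F)ccc2n1C`, has not yet been measured. It differs from compound 2 by trifluoromethyl in place of chloro on an aromatic carbon. For the measured compounds named here, no measured pair shows what this kind of exchange does on this core, so the expectation rests on compound 2 alone. The step from compound 2 to compound 3 in this assay is expected to be small, a 1.1-fold higher number from compound 2 to compound 3 (0.02 log units; within the scatter), with no direction beyond the usual scatter. Compound 3 is accordingly estimated at 2000 nM, within a range from 700 nM to 6000 nM.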

Compound 3, half-maximal inhibitory concentration: 150 nM
Beside the measured number, compound 3's estimate is 13-fold (1.12 log units) above it; the measured number lies below the stated range.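

On this aromatic carbon of the six-membered ring of carbon only, the exchange of chloro for trifluoromethyl gives, in this assay, a 13-fold lower number from compound 2 to compound 3 (1.10 log units; beyond the scatter) and so shows that inhibition on the shared core depends strongly on the group held at this place. Among the compounds shown here, compound 2 alone could not show this, since it offered one group at this place and no step to read. Nothing shown gives a reason for the size of this step, which stands as an observation on one pair.

As far as these compounds go, it remains open how other groups on this same carbon would behave, such as methyl, methoxy, a nitrile or a bromine atom, and whether any of them would go further than trifluoromethyl. Also open, from the compounds shown here alone, is whether the same exchange would have a comparable effect on the other carbons of this ring.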